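The compounds below may be only part of what the source reports. "The series", "measured", "known", "first", "only" and "open" are said of these compounds alone.

Working notes on the series. Compound 3 `C[C@@H](Cn1ccc(-c2ccc(C#N)c(Cl)c2)n1)Nc1ccccc1` gives 710 nM in a functional assay on LNCaP cells (Homo sapiens) for antiproliferative activity, read by CCK-8 assay, with a stated time of 6 days (on this read-out lower numbers stand for stronger inhibition and higher numbers for weaker inhibition), and holds the lowest of the two numbers in hand. The nearest number belongs to compound 1 `C[C@@H](Cn1ccc(-c2ccc(C#N)c(Cl)c2)n1)NS(=O)(=O)c1cccnc1`, which gives 6140 nM in this assay; exchanging its (pyridin-3-yl)sulfonyl on the amine nitrogen for phenyl yields an 8.6-fold lower number from compound 1 to compound 3 (0.94 log units; beyond the scatter). Compound 2 `C[C@@H](Cn1ccc(-c2ccc(C#N)c(Cl)c2)n1)NS(=O)(=O)c1cn(C)cn1` gives only a limit in this assay, > 30000 nM. This is the limit described as the limit of > 30000 nM in this assay, at which 1 of the 3 values shown sits. Against that limit, the step from pyridin-3-yl to 1-methyl-1H-imidazol-4-yl on the sulfonyl sulfur reads an at least 4.8-fold higher number from compound 1 to compound 2 (0.68 log units; beyond the scatter), and the step to the anilino compound reads an at least 42-fold lower number from compound 2 to compound 3 (1.62 log units; beyond the scatter).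

Compound 4 `C[C@@H](Cn1ccc(-c2ccc(C#N)c(Cl)c2)n1)Nc1cncnc1` differs from compound 3 by pyrimidin-5-yl in place of phenyl on an amine nitrogen. Among the compounds with values here, no measured step covers a nitrogen-containing six-membered ring directly on the amine nitrogen of the anilino type, so the expectation rests on analogy: within the sulfonyl pair, moving from pyridin-3-yl to a more nitrogen-rich heteroaryl gave an at least 4.8-fold higher number from compound 1 to compound 2 (0.68 log units; beyond the scatter), a rise in the number beyond the scatter. A rise of smaller size is therefore expected here, and the step from compound 3 to compound 4 is estimated at a 3.5-fold higher number from compound 3 to compound 4 (0.55 log units; beyond the scatter) in this assay. Compound 4 is expected to give about 2500 nM in this assay, within a range of 700 nM to 9000 nM.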

Compound 4, half-maximal inhibitory concentration: 2070 nM
For compound 4 the middle estimate is 1.2-fold (0.08 log units) above the measured one, and the stated range covers the measured number.
By their numbers in this assay, from the lowest: compound 3; then compound 4; then compound 1. At a limit, above all of these: compound 2.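

Pyrimidin-5-yl in place of phenyl on the amine nitrogen keeps the ring directly on that nitrogen and changes only the ring itself, and in this assay this gives a 2.9-fold higher number from compound 3 to compound 4 (0.46 log units; beyond the scatter), so the anilino compound keeps the lower number. Even so, the (pyrimidin-5-yl)amino compound stays ahead of both sulfonyl compounds, with a 3.0-fold lower number from compound 1 to compound 4 (0.47 log units; beyond the scatter) and an at least 14-fold lower number from compound 2 to compound 4 (1.16 log units; beyond the scatter), so among the compounds shown, a ring directly on the amine nitrogen, whether phenyl or pyrimidin-5-yl, gives a lower number than either sulfonyl group. The value of compound 2 is a limit of the assay and not a number: the limit of > 30000 nM in this assay, at which 1 of the 4 values shown sits.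

Still open, on these data alone, is how the number moves with a single ring nitrogen, as with pyridin-3-yl set directly on the amine nitrogen, and with substituents such as fluoro or methoxy on the phenyl ring. Also open, as far as these compounds go, is how a saturated ring such as cyclohexyl on that nitrogen would read, and whether phenylsulfonyl would separate the effect of the sulfonyl link from that of the ring it carries.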